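The source may report more compounds than this note shows. Statements on the series, on what has been measured and on what is new or still open speak of the compounds shown alone.

In a functional assay on HepG2 cells (Homo sapiens) for cytotoxicity, with a stated time of 72 h (a lower number here means that less compound is needed, a higher number that more compound is needed for the effect), compound 1 (`C=C[C@@](C)(/C=C/c1ccc(O)c(C=O)c1)CCC=C(C)C`) gives > 52000 nM as a limit and not a number. Compound 2 (`C=C[C@@](C)(/C=C/c1ccc(O)c(/C=C/C#N)c1)CCC=C(C)C`) gives > 52000 nM as a limit too. Compound 3 (`C=C[C@@](C)(/C=C/c1ccc(O)c(/C=C/C(N)=O)c1)CCC=C(C)C`) likewise gives > 52000 nM as a limit. Compound 3 therefore has no number of its own and stands with the other two on the limit of > 52000 nM in this assay, at which 3 of the 3 values shown sit, as the whole of the evidence so far.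

The next structure is compound 4 (`C=C[C@@](C)(/C=C/c1ccc(O)c(/C=C(\C)C(=O)OCC)c1)CCC=C(C)C`). The change is 2-(ethoxycarbonyl)prop-1-en-1-yl in place of 2-carbamoylethenyl on an aromatic carbon and so the ethyl ester side chain of compound 4 is larger by count than the group it replaces.

Among the measured compounds shown here, three measured steps bear on this change. Replacing the group on an aromatic carbon gave a step that the two limits leave unreadable from compound 1 to compound 2 and a step that the two limits leave unreadable from compound 1 to compound 3 while exchanging cyano for carbamoyl gave a step that the two limits leave unreadable from compound 2 to compound 3 as well. None of them has a readable size, so they offer no firm direction for the change in this assay and only weak grounds for expecting a move to a lower number.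

Compound 4 will most likely stay at or near the same limit. The estimated step is an at least 1.1-fold lower number from compound 3 to compound 4 (0.06 log units; that floor lies within the scatter) and it should be read as loose. For compound 4 the expected value is 45000 nM within an estimated range from 20000 nM to 60000 nM as the working figure.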

Compound 4, half-maximal effective concentration: > 52000 nM
Compound 4 ended at the assay's limit; the forecaster's own chance of this, stated with the estimate: 60%; at least 1.1-fold (0.06 log units) between middle value and limit.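

No step among compound 1, compound 2, compound 3 and compound 4 can be read in this assay, since all four stand on a limit and not on a number: the limit of > 52000 nM in this assay, at which 4 of the 4 values shown sit.

The compounds shown leave open whether any side chain at this aromatic carbon of the shared core gives a measurable value in this assay, and how large any difference among these four groups would be.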